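A few compounds are considered here, and "the series" means these few. Any claim that something is new, unique, unknown or untested is made for them only; others in the source may bear on it.

Working notes on a small series built on one shared core. Compound 1 `COC(=O)c1sc2cc(-c3ccc(OC)nc3)cnc2c1N` is tested in a functional assay on NCI-H460 cells (Homo sapiens) for inhibition, read by sulforhodamine B assay, with a stated time of 48 h; on this read-out lower numbers stand for stronger inhibition of growth and higher numbers for weaker inhibition of growth; for compound 1 the read-out of > 37500 nM is a limit of the assay, not a number. Compound 3 `COC(=O)c1sc2cc(-c3ccc4ncccc4c3)cnc2c1N` likewise returns only a limit in this assay, > 150000 nM. Compound 2 `COC(=O)c1sc2cc(-c3ccc(F)nc3)cnc2c1N` has no number of its own in this assay; its record reads "not determined" (no result reported), so compound 2 stands nowhere on the scale. The two further values around it are both limits, one at the limit of > 37500 nM in this assay, at which 1 of the 3 values shown sits, and one at the limit of > 150000 nM in this assay, at which 1 of the 3 values shown sits. Going by the values given here, no step between measured compounds can be drawn from this set.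

Compound 4 `COC(=O)c1sc2cc(-c3ccc(N)cc3)cnc2c1N` is not yet measured. It differs from compound 2 by 4-aminophenyl in place of 6-fluoropyridin-3-yl on an aromatic carbon. With compound 2 unquantified and compounds 1 and 3 at limits, no size or direction of step in this assay can be anchored; the expectation is a result close to the limits already seen rather than a change beyond the scatter. Compound 4 is estimated at 50000 nM, with a range from 10000 nM to 200000 nM, and a limit-only result is judged likely.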

Compound 4, concentration for 50% growth inhibition: 37100 nM
Compound 4: the middle estimate sits 1.3-fold (0.13 log units) above what was measured; the measured number falls inside the stated range.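

Going by these compounds alone, no step from compound 2 to compound 4 can be read in this assay: the record of compound 2 holds no number, so compound 4 at 37100 nM stands unpaired. The compounds shown leave open how 4-aminophenyl and 6-fluoropyridin-3-yl compare on the shared core.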